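Replacing the Amine Side Group with an Imidazole Ring

A few compounds are considered here, and "the series" means these few. Any claim that something is new, unique, unknown or untested is made for them only; others in the source may bear on it.

Measured so far:
compound 1, `O=C(CNc1ccc(F)cc1)Nc1nc2ccc(Cl)cc2s1`: 300 mg/kg
compound 2, `CC(C)(C)NCC(=O)Nc1nc2ccc(Cl)cc2s1`: 300 mg/kg

Both measured compounds share the same core and differ only in the group attached to the amine nitrogen of the side chain. In a functional assay on the whole organism with Mus musculus as the target, with a stated time of 4 h (on this read-out higher numbers stand for an effect only at larger amounts of compound and lower numbers for an effect already at smaller amounts), compound 1 gives 300 mg/kg. In this assay compound 2 gives 300 mg/kg. Within the data shown here, the single measured step, tert-butyl in place of 4-fluorophenyl on an amine nitrogen, gives no change at the digits printed from compound 1 to compound 2 (within the scatter). Compound 2 therefore stands level with compound 1 on the numbers shown; neither can be called stronger or weaker.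

Compound 3, `O=C(Cn1ccnc1)Nc1nc2ccc(Cl)cc2s1`, is not yet measured. Compared with compound 2 the change is 1H-imidazol-1-yl in place of (tert-butyl)amino on a saturated chain carbon bound to a carbonyl carbon. Among the measured compounds shown here, no measured step covers this exact exchange: the one step available altered the substituent on the amine nitrogen while the amine itself stayed, whereas here the (tert-butyl)amino group leaves altogether and an aromatic ring enters. For the measured compounds named here, the only evidence is that varying this part of the chain left the read-out unchanged, so the expected step for compound 3 is no change at the digits printed from compound 2 to compound 3 (within the scatter), without a clear direction. Compound 3 is thus estimated at 300 mg/kg, with a range from 100 mg/kg to 1000 mg/kg.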

Compound 3, minimum effective dose: 100 mg/kg
Beside the measured number, compound 3's estimate is 3.0-fold (0.48 log units) above it; measured number inside the range.
By their numbers in this assay, from the lowest: compound 3; then compounds 1 and 2 (each within the scatter of the next).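

In this assay, this place on the saturated chain carbon bound to a carbonyl carbon now proves able to move the read-out: the earlier step changed only the substituent on the amine nitrogen and left the number level, whereas replacing the (tert-butyl)amino group with 1H-imidazol-1-yl gives a 3.0-fold lower number from compound 2 to compound 3 (0.48 log units; beyond the scatter) and so a modest gain in effect at smaller amounts of compound. The two groups have the same number of heavy atoms, so the step does not come with a difference in that count; they differ instead in the aromatic ring, the second nitrogen and the loss of the hydrogen-bond donor, and this single exchange changes all of these at once. No measurement given here bears on why the number moved.

Going by these compounds, it remains open whether the imidazole ring itself matters or whether removing the secondary amine is enough, a question that a pyrazol-1-yl group or a dimethylamino group at the same place could help to separate. On these data alone, it is also open how the read-out would respond to a longer chain between the carbonyl and the imidazole ring.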